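Swapping an Aryl Ether for an Indole in a Cytotoxicity Series

This account rests on a few compounds, and the source may have more. Where it says the series, first, only, none or still open, it means among the compounds named here.

Compound 1, `CCOC(=O)CCCCCOc1cccc(CN(C(=O)c2ccc(-c3cccc(OCC(C)C)c3)cc2)C(C)C)c1`: > 26000 nM
Compound 2, `CCOC(=O)CCCCCOc1cccc(CN(C(=O)c2ccc(-c3cccc(Oc4ccccc4)c3)cc2)C(C)C)c1`: > 26000 nM
Compound 3, `CCOC(=O)CCCCCOc1cccc(CN(C(=O)c2ccc(-c3cccc(OCc4ccccc4)c3)cc2)C(C)C)c1`: > 26000 nM

These three compounds share one core and differ only in the group attached to the outer aromatic ring. In an ADME assay on HepG2 cells (Homo sapiens) for cytotoxicity, read by CellTiter-Glo and resazurin assay, with a stated time of 72 h (a higher number here means that more compound is needed for the effect, a lower number that less compound is needed), compound 1 gives > 26000 nM, which is a limit of the assay and not a number. Compound 2 likewise sits at a limit, > 26000 nM. Compound 3 also stands at a limit, > 26000 nM. Compound 1 therefore stands where the whole set stands: at the limit of > 26000 nM in this assay, at which 3 of the 3 values shown sit. The steps between the measured compounds, a step that the two limits leave unreadable from compound 1 to compound 2, a step that the two limits leave unreadable from compound 1 to compound 3 and a step that the two limits leave unreadable from compound 2 to compound 3, have no readable size for that reason.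

Compound 4, `CCOC(=O)CCCCCOc1cccc(CN(C(=O)c2ccc(-c3ccc4cc[nH]c4c3)cc2)C(C)C)c1`, has not yet been measured. It differs from compound 1 in one place: 1H-indol-6-yl in place of 3-(isobutoxy)phenyl on an aromatic carbon. Within the data shown here, none of the measured steps makes this kind of change, so they bear on the step from compound 1 to compound 4 only in a loose way: every variation of this outer group so far has left the value at the limit. No step beyond the scatter is expected in this assay, in either direction. Compound 4 is therefore estimated at 26000 nM, with a range from 10000 nM to 80000 nM, most likely reported again as a limit. The expected step is a number no higher from compound 1 to compound 4 (the limit leaves the size open), essentially none.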

Compound 4, half-maximal effective concentration: > 26000 nM
Compound 4 gave a limit, no number; the forecaster's own chance of this, stated with the estimate: 75%; the middle value lies on the limit itself.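

Compound 4 gives > 26000 nM, which is a limit of this assay and not a number. Among these compounds, no step from compound 1 to compound 4 can be read, as every value here is a limit: the limit of > 26000 nM in this assay, at which 4 of the 4 values shown sit. As far as these compounds go, the concentration at which compound 1, compound 2, compound 3 or compound 4 would produce the effect remains open, as does any difference between them.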